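This account rests on a few compounds, and the source may have more. Where it says the series, first, only, none or still open, it means among the compounds named here.

Working notes on the series. Compound 1 `COc1ccc(-c2cc(C(=O)/C=C/c3ccccc3)nc3cc(-c4ccccc4)nn23)cc1OC` gives 18600 nM in a functional assay on A549 cells (Homo sapiens) for antiproliferative activity, read by MTT assay, with a stated time of 24 h; on this read-out higher numbers stand for weaker inhibition and lower numbers for stronger inhibition. Compound 2 `COc1ccc(-c2cc(C(=O)/C=C/c3ccc(C)cc3)nc3cc(-c4ccccc4)nn23)cc1OC` gives 22200 nM in this assay. Compound 3 `COc1cc(-c2cc(/C=C/C(=O)c3ccc(C)cc3)nc3cc(-c4ccccc4)nn23)cc(OC)c1OC` has a core that differs from that of compound 2 in a way not broken down here; in this assay compound 3 gives 19400 nM, and all three numbers lie within the scatter of one another. The step of a 1.2-fold lower number from compound 2 to compound 1 (0.08 log units; within the scatter) rests on the change (hydrogen in place of methyl on an aromatic carbon). Compound 4 `COc1cc(-c2cc(/C=C/C(=O)c3ccccc3)nc3cc(-c4ccccc4)nn23)cc(OC)c1OC` is not yet measured; it differs from compound 3 by hydrogen in place of methyl on an aromatic carbon, the same change as from compound 2 to compound 1. Because a 1.2-fold lower number from compound 2 to compound 1 (0.08 log units; within the scatter) lay within the scatter, the step from compound 3 to compound 4 is expected to be small as well, estimated as a 1.1-fold lower number from compound 3 to compound 4 (0.06 log units; within the scatter). In this assay compound 4 is therefore estimated at 17000 nM, with a range from 8000 nM to 40000 nM.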

Compound 4, half-maximal inhibitory concentration: 18200 nM
Compound 4: middle estimate off by 1.1-fold (0.03 log units), on the low side; measured number inside the range.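

In this assay, hydrogen in place of methyl on an aromatic carbon gives a 1.1-fold lower number from compound 3 to compound 4 (0.03 log units; within the scatter), and the same change can now be compared on two cores: the same change on two cores in this assay, a 1.2-fold lower number (0.08 log units; within the scatter) from compound 2 to compound 1 and a 1.1-fold lower number (0.03 log units; within the scatter) from compound 3 to compound 4, 1.1-fold (0.05 log units) apart, within the scatter of two such steps. On these two cores, the change therefore reads as the same small step, with the numbers staying within the scatter each time. This does not show that the step would carry over to other cores, and with neither step beyond the scatter, it does not show that a step of clear size carries from one core to another.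

The compounds shown leave open what an amine, a carboxylic acid or a longer chain would give in place of the methyl group of the 4-methylphenyl ring. They also leave open how hydrogen in place of methyl reads on any further core.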